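Amide variation on compound 1: lipophilicity notes

The source may hold more compounds than are shown below. What is called first, only, known or untested is meant among the compounds shown, and "the series" means these compounds.

Measured so far:
compound 1 `CCn1c(-c2cnc(C)nc2)nc2c(N[C@H]3CCN(C(=O)C4CC(F)(F)C4)C3)ncnc21` — 1.5
compound 2 `CCn1c(-c2ccc(C(F)(F)F)nc2)nc2c(O[C@H]3CCN(C(=O)N4CC(OC)C4)C3)ncnc21` — 2.1

In a physicochemical assay for lipophilicity, read by HPLC (on this read-out higher numbers stand for higher lipophilicity and lower numbers for lower lipophilicity), compound 1 gives 1.5, the lower of the two measured values; compound 2 gives 2.1, a number higher by a margin beyond the scatter. Among the compounds with values here, no pair of measured compounds differs in only one place, so no measured step is available.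

Compound 3 `CCC(=O)N1CC[C@H](Nc2ncnc3c2nc(-c2cnc(C)nc2)n3CC)C1` is not yet measured. It differs from compound 1 as counted in ethyl in place of 3,3-difluorocyclobutyl on a carbonyl carbon: the group leaving is 3,3-difluorocyclobutyl, the group entering is ethyl, on a carbonyl carbon whose other neighbour is an amide-type nitrogen in a ring. Within the data shown here, with no measured step to draw on, the expected change is a modest decrease, slightly larger than the scatter. The step from compound 1 to compound 3 is expected to be a number 0.40 log units lower from compound 1 to compound 3 (beyond the scatter). Compound 3 is accordingly estimated at 1.1, with a range from 0.7 to 1.5.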

Compound 3, distribution coefficient: 0.7
Compound 3: the middle estimate sits 0.40 log units above what was measured, and the stated range covers the measured number.
By their numbers in this assay, from the lowest: compound 3; then compound 1; then compound 2.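

Within the data shown here, compound 3 supplies the first measured step at this position: in this assay, ethyl in place of 3,3-difluorocyclobutyl on a carbonyl carbon reads a number 0.80 log units lower from compound 1 to compound 3 (beyond the scatter). The read-out therefore responds to the group on this carbonyl carbon alone, with the rest of compound 1 unchanged. No evidence at hand bears on the reason for this step.

Among these compounds, the single step changes several things at once, losing the ring, the fluorine atoms and part of the heavy-atom count, so it remains open which of these carries it; plain cyclobutyl or a longer chain such as butyl on the same carbonyl carbon would separate them. Going by these compounds, it also remains open how an acyl group carrying an amine or a carboxylic acid would read here.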